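Replacing the Phenyl with 4-Methoxybenzyl on a Ring Nitrogen

The source may report more compounds than this note shows. Statements on the series, on what has been measured and on what is new or still open speak of the compounds shown alone.

Going by the values given here, of the two compounds measured so far, compound 2 `Cn1c(-c2ccc(NC(=O)CN3CCN(c4ccccc4)CC3)cc2)nc(-c2ccccc2)c1-c1ccccc1` holds the higher number. Among the compounds with values here, in a functional assay on MCF7 cells (Homo sapiens) for cytotoxicity, read by MTT assay, with a stated time of 24 h, tested at 16 ug/mL (on this read-out higher numbers stand for a stronger effect at the one concentration tested and lower numbers for a weaker effect), compound 2 gives 59.6%, while compound 1 `Cn1ccnc1SCC(=O)Nc1ccc(-c2nc(-c3ccccc3)c(-c3ccccc3)n2C)cc1` in this assay gives 32.4%; the one measured step, a number 27.2 percentage points higher from compound 1 to compound 2 (beyond the scatter), separates them. That step changed the group on the saturated chain carbon bound to the carbonyl carbon, so it says nothing about the spot altered here.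

Compound 3 `COc1ccc(CN2CCN(CC(=O)Nc3ccc(-c4nc(-c5ccccc5)c(-c5ccccc5)n4C)cc3)CC2)cc1` differs from compound 2 at the amine nitrogen in a ring: 4-methoxybenzyl in place of phenyl on an amine nitrogen in a ring. Within the data shown here, no measured step bears on this exchange, so there is no ground for expecting a shift in either direction in this assay; the step of a number 4.6 percentage points lower from compound 2 to compound 3 (within the scatter) is expected to stay within the scatter. Compound 3 is therefore estimated at 55%, within a range of 35% to 75%.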

Compound 3, a percentage reported as activity, at one concentration (the size of the read-out at that concentration, not a potency): 12%
Beside the measured number, compound 3's estimate is 43 percentage points above it, and the stated range ends above it.
By their numbers in this assay, from the lowest: compound 3; then compound 1; then compound 2.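

In this assay the exchange of phenyl for 4-methoxybenzyl on the amine nitrogen in the ring gives a number 47.6 percentage points lower from compound 2 to compound 3 (beyond the scatter) so the read-out proves sensitive to the group carried on this nitrogen. The earlier step changed only the group on the saturated chain carbon, whereas this one shows that a change on the ring nitrogen, with the rest of the molecule held the same, can also move the number well beyond the scatter. Nothing measured here explains the drop.

On these data alone, this single exchange alters the group in more than one way, so it remains open whether the methoxy or the carbon linking the ring to the nitrogen matters. A plain benzyl or a 4-methoxyphenyl group on the same nitrogen would separate these two parts.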